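The source may report more compounds than this note shows. Statements on the series, on what has been measured and on what is new or still open speak of the compounds shown alone.

Compound 1 `C/N=C(\S)CCn1nc(-c2ccccc2)ccc1=O` and compound 2 `CC/N=C(\S)CCn1nc(-c2ccccc2)ccc1=O` share one core; in a functional assay on the whole organism (stomach) for inhibition, with Rattus norvegicus as the target, at a dose of 100 mg/kg by the intraduodenal route (a higher number here means more inhibition at the dose given (going by the name of the read-out), a lower number less inhibition), compound 1 gives 68.2% and compound 2 gives 50.3%. The step of a number 17.9 percentage points higher from compound 2 to compound 1 (beyond the scatter) comes from the change (hydrogen in place of methyl on a saturated chain carbon bound to a double-bonded nitrogen). Compound 3 `Cc1ccc(=O)n(C(C)CC(=N)S)n1` has a different core, and the difference between the two cores is not broken down here; in this assay compound 3 gives 32.5%. Compound 4 `Cc1ccc(=O)n(CCC(=N)S)n1` differs from compound 3 by hydrogen in place of methyl on a saturated chain carbon bound to an aromatic nitrogen and a saturated chain carbon. This is the same kind of change as from compound 2 to compound 1, but not the same: there the place was on a saturated chain carbon bound to a double-bonded nitrogen, here it is on a saturated chain carbon bound to an aromatic nitrogen and a saturated chain carbon. A step of about a number 13.5 percentage points higher from compound 3 to compound 4 (beyond the scatter) is expected from compound 3 to compound 4, resting on the measured step of a number 17.9 percentage points higher from compound 2 to compound 1 (beyond the scatter). For compound 4 in this assay the estimate is 46%, with 28% to 64%.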

Compound 4, a percentage reported as inhibition, in the whole organism at one dose (the size of the read-out at that dose, not a potency): 73.9%
The estimate for compound 4 lay 27.9 percentage points below the measured number, outside the stated range (above it).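

In this assay, hydrogen in place of methyl gives a number 41.4 percentage points higher from compound 3 to compound 4 (beyond the scatter), the same direction as the earlier step, but the size does not carry over from one core to the other: the same change on two cores in this assay, a number 17.9 percentage points higher (beyond the scatter) from compound 2 to compound 1 and a number 41.4 percentage points higher (beyond the scatter) from compound 3 to compound 4, 23.5 percentage points apart, beyond the scatter of two such steps. The direction is therefore shared by these two pairs only, and a step measured on one core is a poor guide to the size of the step on the other. The change also sits at a different place in each pair, so two pairs cannot show whether the core or the place sets the size.

As far as these compounds go, it remains open how a longer chain such as propyl, or an amine, would behave on the saturated chain carbon bound to an aromatic nitrogen and a saturated chain carbon.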